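Trifluoromethyl for methoxy on the pyridine of compound 2

The source may hold more compounds than are shown below. What is called first, only, known or untested is meant among the compounds shown, and "the series" means these compounds.

Compound 2, `COc1ccc(-c2nc(C(F)(F)F)sc2N2CCN(C(=O)Cn3nc(C)nc3C)[C@H](C)C2)cn1`, is the weaker of the two measured compounds in an assay on blood for inhibition of C-X-C chemokine receptor type 3 (Homo sapiens), with a stated time of 30 min (on this read-out lower numbers stand for stronger inhibition and higher numbers for weaker inhibition), where compound 2 gives 1580 nM, while compound 1, `Cc1ncc(-c2nc(C(F)(F)F)sc2N2CCN(C(=O)Cn3nc(C)nc3C)[C@H](C)C2)cn1`, gives 610 nM. Within the data shown here, the only measured step, a 2.6-fold higher number from compound 1 to compound 2 (0.41 log units; beyond the scatter), exchanges the whole six-membered ring and does not touch a methoxy or trifluoromethyl group, so it bears on the next change only indirectly. Compound 3, `Cc1nc(C)n(CC(=O)N2CCN(c3sc(C(F)(F)F)nc3-c3ccc(C(F)(F)F)nc3)C[C@H]2C)n1`, differs from compound 2 by trifluoromethyl in place of methoxy on an aromatic carbon, the new group sitting next to the ring nitrogen and para to a large group. Among the measured compounds shown here, no measured pair tests this exchange, so the direction of its effect is not known from these data. Compound 3 is therefore expected to land close to compound 2, with a 1.6-fold lower number from compound 2 to compound 3 (0.20 log units; within the scatter) as the estimated step, and a wide range: compound 3 is estimated at 1000 nM, between 300 nM and 3500 nM.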

Compound 3, half-maximal inhibitory concentration: 860 nM
The estimate for compound 3 lay 1.2-fold (0.07 log units) above the measured number; measured number inside the range.
By their numbers in this assay, from the lowest: compounds 1, 3 and 2 (each within the scatter of the next, the first and the last beyond it).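

In this assay the carbon next to the ring nitrogen accepts either group without a readable difference: trifluoromethyl in place of methoxy gives a step within the scatter (a 1.8-fold lower number from compound 2 to compound 3 (0.26 log units; within the scatter)). The 6-(trifluoromethyl)pyridin-3-yl group of compound 3 also cannot be told apart from the 2-methylpyrimidin-5-yl group of compound 1 (a 1.4-fold higher number from compound 1 to compound 3 (0.15 log units; within the scatter)), even though the step between the other two compounds lies beyond the scatter (a 2.6-fold higher number from compound 1 to compound 2 (0.41 log units; beyond the scatter)). Nothing available accounts for these numbers.

As far as these compounds go, it remains open whether a chlorine atom, a nitrile or an amine on this carbon would stand apart from methoxy and trifluoromethyl. From the compounds shown here alone, it is also open whether the exchange of methoxy for trifluoromethyl would give a similar step on another carbon of the pyridine.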